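The source may report more compounds than this note shows. Statements on the series, on what has been measured and on what is new or still open speak of the compounds shown alone.

Measured so far:
compound 1, `c1ccc(CNCc2cn(Cc3ccccc3)c3ccccc23)cc1` — 245000 nM
compound 2, `CC#CCN(C)Cc1cc2cc(O)ccc2n1C` — 5.75 nM

In an assay on isolated protein for inhibition of Amine oxidase [flavin-containing] A (Rattus norvegicus) (on this read-out higher numbers stand for weaker inhibition and lower numbers for stronger inhibition), compound 1 stands at the higher of the two numbers, far above compound 2. Compound 3, `C#CCN(C)Cc1cn(Cc2ccccc2)c2ccccc12`, differs from compound 1 by methyl(propargyl)amino in place of benzylamino on a saturated chain carbon bound to an aromatic carbon. For the measured compounds named here, no step between measured compounds exists, but compound 2 carries a related alkyne-bearing amine and gives 5.75 nM, so the change is expected to lower the number well beyond the scatter. Compound 3 is estimated at 200 nM, between 15 nM and 3000 nM, a step of a 1200-fold lower number from compound 1 to compound 3 (3.09 log units; beyond the scatter).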

Compound 3, inhibition constant: 158000 nM
Compound 3: middle estimate off by 790-fold (2.90 log units), on the low side, outside the stated range (above it).
By their numbers in this assay, from the lowest: compound 2; then compounds 3 and 1 (each within the scatter of the next).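

Read in this assay, methyl(propargyl)amino in place of benzylamino on a saturated chain carbon bound to an aromatic carbon gives a 1.6-fold lower number from compound 1 to compound 3 (0.19 log units; within the scatter) and so leaves the two compounds indistinguishable. On the core of compound 1, then, an amine with a triple bond is not enough by itself to bring the number down. On these data alone, whether a dimethylamino group or a longer chain on the nitrogen would give a different number at this position stays open. Nothing measured explains this result.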